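Trifluoromethoxy in Place of Fluoro: Expected Cytotoxicity

This account rests on a few compounds, and the source may have more. Where it says the series, first, only, none or still open, it means among the compounds named here.

Two compounds sharing one core have been examined in an ADME assay on Vero cells (Chlorocebus sabaeus) for cytotoxicity, with a stated time of 72 h; on this read-out higher numbers stand for weaker inhibition and lower numbers for stronger inhibition. Compound 1 `O=[N+]([O-])c1cn2c(n1)OC[C@@H](OCc1nnn(-c3ccccc3)n1)C2` reaches only a limit of the assay there, > 128000 nM. Compound 2 `O=[N+]([O-])c1cn2c(n1)OC[C@@H](OCc1nnn(-c3ccc(F)cc3)n1)C2` differs from compound 1 by fluoro in place of hydrogen on an aromatic carbon. In this assay compound 2 likewise gives only a limit, > 128000 nM. The step that the two limits leave unreadable from compound 1 to compound 2 is therefore of unreadable size. Compound 2 thus stands at the limit, the point at which both measured values sit (the limit of > 128000 nM in this assay, at which 2 of the 2 values shown sit).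

Compound 3 `O=[N+]([O-])c1cn2c(n1)OC[C@@H](OCc1nnn(-c3ccc(OC(F)(F)F)cc3)n1)C2` differs from compound 2 by trifluoromethoxy in place of fluoro on an aromatic carbon. For the measured compounds named here, the single measured step, a step that the two limits leave unreadable from compound 1 to compound 2, bears on this change only loosely and gives no readable size or direction. With nothing pointing either way in this assay, compound 3 is expected to give about 160000 nM, between 60000 nM and 450000 nM, with an expected step that the limit leaves unreadable from compound 2 to compound 3, most likely again reported as a limit rather than a number.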

Compound 3, half-maximal inhibitory concentration: > 128000 nM
Compound 3: no number, only a limit; the forecaster's own chance of this, stated with the estimate: 80%; the middle value lies beyond the limit too.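

Compound 3 gives only a limit in this assay, as do compound 1 and compound 2, so no step among the three can be read: the limit of > 128000 nM in this assay, at which 3 of the 3 values shown sit.

Left open is how far each compound lies past that limit, and whether the three differ at all in this assay.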